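The source may hold more compounds than are shown below. What is called first, only, known or untested is meant among the compounds shown, and "the series" means these compounds.

Of the compounds shown here, two of the shared core have been measured in a functional assay on EKVX cells (Homo sapiens) for inhibition, with a stated time of 48 h (a higher number here means a weaker inhibitor of growth, a lower number a stronger inhibitor of growth), so far, and each of them stopped at the top of the assay. Compound 1 `NNC(=O)c1c(NC(=O)NS(=O)(=O)c2ccccc2)sc2c1CCCCC2` gives > 100000 nM, which is a limit of the assay rather than a number. Compound 2 `O=C(Nc1sc2c(c1C(=O)NNc1ccc(Br)cc1)CCCCC2)NS(=O)(=O)c1ccccc1` gives > 100000 nM, again a limit of the assay. Between them lies a step that the two limits leave unreadable from compound 1 to compound 2, so the only step measured so far tells nothing of its own size; the one piece of evidence is the limit of > 100000 nM in this assay, at which 2 of the 2 values shown sit. Compound 3 `O=C(Nc1sc2c(c1C(=O)N1CCN(c3ccccc3)CC1)CCCCC2)NS(=O)(=O)c1ccccc1` differs from compound 2 by 4-phenylpiperazin-1-yl in place of ((4-bromophenyl)amino)amino on a carbonyl carbon. Within the data shown here, no measured step bears on this change, since the sole step available is unreadable. Among the measured compounds shown here, compound 3 is therefore expected near the same upper edge, with an estimate of 80000 nM in this assay, spanning 15000 nM to 400000 nM, and an expected step of an at least 1.2-fold lower number from compound 2 to compound 3 (0.09 log units; that floor lies within the scatter) that cannot be distinguished from no step at all.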

Compound 3, concentration for 50% growth inhibition: > 100000 nM
Compound 3: only a limit was reported; the forecaster's own chance of this, stated with the estimate: 65%; middle value at least 1.2-fold (0.09 log units) from the limit.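

In this assay compound 3 gives > 100000 nM, again a limit of the assay and not a number. Among these compounds, no step from compound 1 or compound 2 to compound 3 can be read. The compounds shown leave open whether any group on the carbonyl carbon brings growth inhibition within the assay's range.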